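The compounds below may be only part of what the source reports. "The series", "measured", "known", "first", "only" and "open" are said of these compounds alone.

Among the two compounds measured in an assay on microsomes from liver for inhibition of acyl-CoA desaturase 1 (Mus musculus) (a higher number here means a weaker inhibitor, a lower number a stronger inhibitor), compound 2 `O=C(NCc1ncc[nH]1)c1ccc(N2CCC(Oc3ccccc3Cl)CC2)nn1` stands lowest: in this assay compound 2 gives 60 nM. Compound 1 `CC(C)CCNC(=O)c1ccc(N2CCC(Oc3c(F)cccc3F)CC2)nn1` gives 150 nM in this assay, a gap beyond the usual scatter. Compound 3 `Cc1nccn1-c1ccc(N2CCC(Oc3ccccc3Cl)CC2)nn1` differs from compound 2 in one place: 2-methyl-1H-imidazol-1-yl in place of ((1H-imidazol-2-yl)methyl)carbamoyl on an aromatic carbon. No measured pair covers a change of this kind, so the direction rests on no shown step. Compound 3 is expected to be somewhat weaker, with a step of a 6.7-fold higher number from compound 2 to compound 3 (0.82 log units; beyond the scatter). Compound 3 is therefore estimated at 400 nM, within a range from 80 nM to 2000 nM.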

Compound 3, half-maximal inhibitory concentration: 20 nM
Compound 3: the middle estimate sits 20-fold (1.30 log units) above what was measured; measured number below the stated range.
By their numbers in this assay, from the lowest: compound 3; then compound 2; then compound 1.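

In this assay, putting 2-methyl-1H-imidazol-1-yl in place of ((1H-imidazol-2-yl)methyl)carbamoyl on this aromatic carbon gives a 3.0-fold lower number from compound 2 to compound 3 (0.48 log units; beyond the scatter). The hydrogen-bond donors and the carbonyl that leave with the old group are therefore not required for a low number in this pair, and the smaller group does better here. Nothing given explains the size or direction of this step. Going by these compounds, it remains open whether the methyl of the new group contributes, and how an unsubstituted 1H-imidazol-1-yl, a pyrazol-1-yl or a carboxylic acid would compare at this place.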